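Removing a silicon-bearing group from the triazole of compound 1

The source may report more compounds than this note shows. Statements on the series, on what has been measured and on what is new or still open speak of the compounds shown alone.

Compound 1 `C[Si](C)(C)c1cn(C[C@H](O)[C@H]2OC(=O)C(OCc3ccccc3)=C2OCc2ccccc2)nn1` is assessed in a functional assay on HeLa cells (Homo sapiens) for antiproliferative activity, read by MTT assay, with a stated time of 72 h (a higher number here means a weaker inhibitor, a lower number a stronger inhibitor), where compound 1 gives 22300 nM. Among the numbers that are known, compound 1 carries the lowest, although its companion compound 2 `O=C1O/C(=C\Cn2cc(-c3ccc(Br)cc3)nn2)C(OCc2ccccc2)=C1OCc1ccccc1` gives 24300 nM in this assay, a difference that lies within the usual scatter, so the two cannot be ordered. Compound 3 `O=C1O/C(=C\Cn2cc(-c3cc(C(F)(F)F)cc(C(F)(F)F)c3)nn2)C(OCc2ccccc2)=C1OCc1ccccc1` reaches only a limit of this assay, > 100000 nM, and is not a number (the limit of > 100000 nM in this assay, at which 1 of the 3 values shown sits).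

Compound 4 `O=C1O[C@H]([C@@H](O)Cn2ccnn2)C(OCc2ccccc2)=C1OCc1ccccc1` differs from compound 1 in a single place: a hydrogen atom in place of a group of 4 heavy atoms (3 carbon, 1 silicon; no ring), on an aromatic carbon. Within the data shown here, no pair of measured compounds shows this change on its own, so there is no measured step to lean on; the expected size of the step in this assay is modest, and most likely toward a higher number, if it clears the scatter at all. Compound 4 is therefore estimated to give 32000 nM in this assay, with a range from 11000 nM to 95000 nM, a step from compound 1 of a 1.4-fold higher number from compound 1 to compound 4 (0.16 log units; within the scatter) that is expected rather than measured.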

Compound 4, half-maximal inhibitory concentration: > 100000 nM
Compound 4: only a limit was reported (the forecaster's own chance of this, stated with the estimate: 15%); middle value at least 3.1-fold (0.49 log units) from the limit.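

In this assay, a hydrogen atom in place of the group of 4 heavy atoms (3 carbon, 1 silicon; no ring) on an aromatic carbon of the five-membered aromatic ring with 3 nitrogen gives an at least 4.4-fold higher number from compound 1 to compound 4 (0.65 log units; beyond the scatter). Among these compounds, this is the first step that can be read at this position, and it shows that the group standing on this carbon counts for compound 1. The reading of > 100000 nM for compound 4 is a limit of the assay and not a number, and compound 4 is the second compound to sit there: the limit of > 100000 nM in this assay, at which 2 of the 4 values shown sit.

The compounds shown leave open whether the silicon atom itself matters, or whether a tert-butyl group or a methyl group on the same carbon would keep the number of compound 1. From the compounds shown here alone, how far the step reaches beyond its printed size also stays open.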